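A few compounds are considered here, and "the series" means these few. Any claim that something is new, unique, unknown or untested is made for them only; others in the source may bear on it.

Working notes on a series measured in an assay on CHO cells for antagonist activity at transient receptor potential cation channel subfamily V member 1 (Homo sapiens), read by FLIPR; on this read-out lower numbers stand for stronger inhibition and higher numbers for weaker inhibition. Compound 1 `CC(C(=O)NCc1ccc(C(F)(F)F)nc1-c1ccccc1F)c1ccc(NS(C)(=O)=O)c(F)c1` gives 63.3 nM; compound 2 `CC(C(=O)NCc1ccc(C(F)(F)F)nc1-c1ccc(N(C)C)cc1)c1ccc(NS(C)(=O)=O)c(F)c1` gives 3.2 nM; compound 3 `CC(C(=O)NCc1ccc(C(F)(F)F)nc1-c1ccsc1)c1ccc(NS(C)(=O)=O)c(F)c1` gives 2 nM. Compound 2 stands second highest of the three numbers, with compound 3 nearest and compound 1 furthest: a 20-fold lower number from compound 1 to compound 2 (1.30 log units; beyond the scatter), a 32-fold lower number from compound 1 to compound 3 (1.50 log units; beyond the scatter), a 1.6-fold lower number from compound 2 to compound 3 (0.20 log units; within the scatter). Compound 4 `Cc1ccc(CCc2nc(C(F)(F)F)ccc2CNC(=O)C(C)c2ccc(NS(C)(=O)=O)c(F)c2)cc1` has not been measured; its change from compound 2 is 2-(4-methylphenyl)ethyl in place of 4-(dimethylamino)phenyl on an aromatic carbon. Among the measured compounds shown here, no measured step covers this kind of change. The two large steps show that the group at this position shifts the number much, while the step within the scatter shows two of the groups behaving alike. Compound 4 is expected to land somewhat weaker, a step of a 7.8-fold higher number from compound 2 to compound 4 (0.89 log units; beyond the scatter). The estimate for compound 4 is 25 nM, range 4 nM to 160 nM.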

Compound 4, inhibition constant: 0.6 nM
For compound 4 the middle estimate is 42-fold (1.62 log units) above the measured one; the measured number lies below the stated range.
By their numbers in this assay, from the lowest: compound 4; then compounds 3 and 2 (each within the scatter of the next); then compound 1.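

The position accepts an aromatic ring set off on a chain as well as one attached directly: in this assay, 2-(4-methylphenyl)ethyl gives a 5.3-fold lower number from compound 2 to compound 4 (0.73 log units; beyond the scatter) and a 3.3-fold lower number from compound 3 to compound 4 (0.52 log units; beyond the scatter). Against 2-fluorophenyl, the same group gives a 110-fold lower number from compound 1 to compound 4 (2.02 log units; beyond the scatter), the widest step in the series at this position. The data offer no measured explanation for these steps. Open, going by these compounds, is whether the chain or the 4-methylphenyl ring accounts for the lower number. An unsubstituted 2-phenylethyl, a longer 3-phenylpropyl chain or an amine within the chain would separate these.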